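Methyl for hydrogen on a selenium-sugar nucleoside pair

The compounds below may be only part of what the source reports. "The series", "measured", "known", "first", "only" and "open" are said of these compounds alone.

Compound 2 `O=c1ccn([C@@H]2C[Se][C@@H](CO)O2)c(=O)[nH]1` was tested in a functional assay on CCRF-CEM cells (Homo sapiens) for cytotoxicity; on this read-out higher numbers stand for weaker inhibition and lower numbers for stronger inhibition. In this assay compound 2 gives > 100000 nM, which is a limit of the assay rather than a number. Compound 1 `Cc1cn([C@H]2C[Se][C@@H](CO)O2)c(=O)[nH]c1=O` was tested alongside it. In this assay compound 1 gives > 100000 nM, likewise a limit. Compound 2 therefore does not stand at a measured point at all; both values shown sit at the same limit, as stated by the limit of > 100000 nM in this assay, at which 2 of the 2 values shown sit. Compound 3 `Cc1cn([C@@H]2C[Se][C@@H](CO)O2)c(=O)[nH]c1=O` has not yet been measured in this assay. It differs from compound 2 by methyl in place of hydrogen on an aromatic carbon. Within the data shown here, no step between measured compounds is known, so there is no basis for a step beyond the scatter in either direction. The step from compound 2 to compound 3 is estimated as a step that the limit leaves unreadable from compound 2 to compound 3. Compound 3 is expected to give 150000 nM in this assay, within a range of 50000 nM to 500000 nM, most likely again reported only as a limit.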

Compound 3, half-maximal inhibitory concentration: > 100000 nM
Compound 3: a limit, no number; the forecaster's own chance of this, stated with the estimate: 90%; the middle value is on the limit's open side.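

In this assay compound 3 gives > 100000 nM, again a limit of the assay and not a number. Among these compounds, no step from compound 1 or compound 2 to compound 3 can be read: the limit of > 100000 nM in this assay, at which 3 of the 3 values shown sit. The compounds shown leave open whether methyl in place of hydrogen, or the configuration as drawn, changes cytotoxicity at all.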